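A few compounds are considered here, and "the series" means these few. Any claim that something is new, unique, unknown or untested is made for them only; others in the source may bear on it.

Measured compounds:
- Compound 1, `CCCCc1cc(CC)c(O)cc1OCCCCCC(C)(C)c1nnn[nH]1`, in an assay on isolated protein for antagonist activity at Bile acid receptor (Homo sapiens), read by HTRF, with a stated time of 30 min (on this read-out higher numbers stand for weaker inhibition and lower numbers for stronger inhibition), gives 8700 nM
- Compound 2, `CCCCc1cc(C(C)=O)c(OCc2ccccc2)cc1OCCCCCC(C)(C)c1nnn[nH]1`, in this assay gives 7800 nM
- Compound 3, `CCc1cc(C(C)=O)c(OC)cc1OCCCCCC(C)(C)c1nnn[nH]1`, in this assay gives 5500 nM

Compound 3 carries the lowest number of the three in this assay, but the gap to compound 2 and the gap to compound 1 both fall within the usual scatter, so no ordering among the three can be claimed. Among the measured compounds shown here, no pair among the measured compounds differs in a single place, so no single step is available to lean on.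

Compound 4, `CCc1cc(C(C)=O)c(OCc2cccc(C)c2)cc1OCCCCCC(C)(C)c1nnn[nH]1`, is not yet measured. It is obtained from compound 3 by the change (3-methylphenyl in place of hydrogen on a saturated chain carbon bound to an oxygen on an aromatic ring). For the measured compounds named here, the series gives no direct precedent for this change; compound 2 shows that a compound of similar build with a larger group at the corresponding position sits close to compound 3 in this assay, which is the only hint on hand.

For compound 4 in this assay, the step of a 1.1-fold higher number from compound 3 to compound 4 (0.04 log units; within the scatter) from compound 3 is expected to stay within the scatter. Compound 4 is estimated at 6000 nM, with a range of 2500 nM to 15000 nM.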

Compound 4, half-maximal inhibitory concentration: 1200 nM
For compound 4 the middle estimate is 5.0-fold (0.70 log units) above the measured one; measured number below the stated range.
By their numbers in this assay, from the lowest: compound 4; then compounds 3, 2 and 1 (each within the scatter of the next).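

In this assay, replacing methoxy with (3-methylbenzyl)oxy gives a 4.6-fold lower number from compound 3 to compound 4 (0.66 log units; beyond the scatter) and so moves the number toward stronger inhibition. Among the compounds shown here, this is the first single-place change available, and it shows that this position can shift the read-out beyond the scatter, something the earlier compounds could not show, as their values lie within the scatter of one another and no two of them differ in one place only. The 3-methylphenyl group on the saturated chain carbon bound to the oxygen on the aromatic ring is therefore tolerated here and goes with a real gain in this assay, although nothing on hand connects that gain to any measured property of the group.

A single step cannot separate the contribution of the aromatic ring from that of its methyl group, nor show whether the gain carries over to the other substituents found on the core of compound 1. Also open, on these data alone, is how the position would respond to a longer chain between the oxygen and the ring, or to an amine or a carboxylic acid on that ring.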